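Replacing the cyclopropylpyrimidine of compound 3 with a trifluoromethylpyridine

The compounds below may be only part of what the source reports. "The series", "measured", "known", "first", "only" and "open" are said of these compounds alone.

Three close analogues share one core. Compound 1 `Cc1nc(C)n(CC(=O)N2CCN(c3sc(C(F)(F)F)nc3-c3cnc(OC4CCC4)nc3)C[C@H]2C)n1` gives 4 nM in a functional assay on CHO-K1 cells for antagonist activity at C-X-C chemokine receptor type 3 (Homo sapiens), read by FLIPR, with a stated time of 10 min; on this read-out higher numbers stand for weaker inhibition and lower numbers for stronger inhibition. Compound 2 `CCCc1ncc(-c2nc(C(F)(F)F)sc2N2CCN(C(=O)Cn3nc(C)nc3C)[C@H](C)C2)cn1` gives 4.4 nM in this assay, and compound 3 `Cc1nc(C)n(CC(=O)N2CCN(c3sc(C(F)(F)F)nc3-c3cnc(C4CC4)nc3)C[C@H]2C)n1` gives 3.5 nM in this assay. Compound 3 holds the lowest of the three numbers, but its neighbours sit close: a 1.1-fold lower number from compound 1 to compound 3 (0.06 log units; within the scatter) and a 1.3-fold lower number from compound 2 to compound 3 (0.10 log units; within the scatter), and likewise a 1.1-fold higher number from compound 1 to compound 2 (0.04 log units; within the scatter). The three compounds differ only in the group on an aromatic carbon, and none of those swaps moved the read-out beyond the scatter.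

Compound 4 `Cc1nc(C)n(CC(=O)N2CCN(c3sc(C(F)(F)F)nc3-c3ccc(C(F)(F)F)nc3)C[C@H]2C)n1` has not been measured. It differs from compound 3 in one place: 6-(trifluoromethyl)pyridin-3-yl in place of 2-cyclopropylpyrimidin-5-yl on an aromatic carbon. Within the data shown here, no measured step bears directly on this change, since each of the three steps kept the ring found in compound 3 and varied only the group attached to it, whereas here the ring itself and its group change together. Those three steps, each within the scatter, show that this region of the core accepted three different groups without a shift. The change to compound 4 is larger, so the expectation is wider: a modest rise in the number, expected as a 1.7-fold higher number from compound 3 to compound 4 (0.23 log units; within the scatter), with little confidence in direction. Compound 4 is expected to give 6 nM in this assay, within a range from 2 nM to 20 nM.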

Compound 4, half-maximal inhibitory concentration: 4.2 nM
The estimate for compound 4 lay 1.4-fold (0.15 log units) above the measured number; the measured number falls inside the stated range.
By their numbers in this assay, from the lowest: compounds 3, 1, 4 and 2 (each within the scatter of the next).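

Among these compounds, until now, only the group on the pyrimidine ring had varied, so the earlier steps could not show whether the ring itself mattered on this read-out. Compound 4 changes the ring and its group together, dropping one ring nitrogen and the three-membered carbon ring and bringing in a trifluoromethyl group, yet in this assay this swap gives a 1.2-fold higher number from compound 3 to compound 4 (0.08 log units; within the scatter) and the two related swaps give a 1.0-fold lower number from compound 2 to compound 4 (0.02 log units; within the scatter) and a 1.1-fold higher number from compound 1 to compound 4 (0.02 log units; within the scatter), so all four aromatic groups at this carbon of the shared core, next to the ring nitrogen, read alike, and the tolerance seen for the pyrimidines extends to this pyridine. Nothing available here accounts for this lack of separation among the four compounds.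

As far as these compounds go, all four groups are six-membered aromatic rings with at least one ring nitrogen, so it remains open whether the read-out would hold with a plain phenyl ring or a five-membered ring such as a pyrazole at this carbon. From the compounds shown here alone, it is equally open whether a carboxylic acid or an amine in place of the trifluoromethyl group of compound 4 would leave the number where it stands.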